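The source may report more compounds than this note shows. Statements on the series, on what has been measured and on what is new or still open speak of the compounds shown alone.

Compound 1, with the structure `CC1(C)CC(Oc2ccc(C(=O)Nc3ccc(NC(=O)Nc4cc(C(C)(C)C)on4)cc3)nc2)CC(C)(C)N1`, was examined in an ADME assay on the whole organism (plasma, strain Sprague-Dawley) for pharmacokinetics, with Rattus norvegicus as the target, read by LC-MS, at a dose of 10 mg/kg by the oral route (on this read-out lower numbers stand for lower exposure and higher numbers for higher exposure at the dose given), where compound 1 gave 1280 ng.h/mL. This is the higher of the two numbers recorded in this assay: compound 2, with the structure `Cc1ccnc(C(=O)Nc2ccc(NC(=O)Nc3cc(C(C)(C)C)on3)cc2)c1`, gave 197 ng.h/mL in this assay, a lower number that lies beyond the scatter of the measurement. Compound 3, with the structure `CC(C)(C)c1cc(NC(=O)Nc2ccc(NC(=O)c3ccc(OC4CCN(C(C)(C)C)CC4)cn3)cc2)no1`, has not yet been measured. It shares every atom with compound 1 but joins them differently: 1-(tert-butyl)piperidin-4-yl in place of 2,2,6,6-tetramethylpiperidin-4-yl on an oxygen on an aromatic ring. For the measured compounds named here, since no pair of measured compounds shows this change, there is no measured step to lean on, and the expectation rests on compound 1 alone. The step from compound 1 to compound 3 in this assay is expected to be a modest one, most likely downward and not clearly beyond the scatter, as a 1.5-fold lower number from compound 1 to compound 3 (0.18 log units; within the scatter). Compound 3 is therefore estimated to give about 850 ng.h/mL in this assay, within a range from 250 ng.h/mL to 2900 ng.h/mL.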

Compound 3, area under the concentration-time curve: 2670 ng.h/mL
The estimate for compound 3 lay 3.1-fold (0.50 log units) below the measured number, and the stated range covers the measured number.
By their numbers in this assay, from the lowest: compound 2; then compound 1; then compound 3.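

In this assay, 1-(tert-butyl)piperidin-4-yl in place of 2,2,6,6-tetramethylpiperidin-4-yl on an oxygen on an aromatic ring gives a 2.1-fold higher number from compound 1 to compound 3 (0.32 log units; beyond the scatter). Both groups hold the same heavy atoms, so this single step shows that the number at this place can shift with how those atoms are joined, not only with which atoms are present; the entering group also has 0 hydrogen-bond donors where the leaving group has 1. No accompanying measurement bears on why the number moved.

Going by these compounds, it remains open whether the tert-butyl group on the ring nitrogen is needed, or whether a smaller methyl or isopropyl group there would give a similar number. Also open, on these data alone, is how a piperidin-4-yl with a free ring nitrogen would compare on the same oxygen.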